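This account rests on a few compounds, and the source may have more. Where it says the series, first, only, none or still open, it means among the compounds named here.

Measured so far in a functional assay on NCI-H460 cells (Homo sapiens) for cytotoxicity, read by sulforhodamine B assay; on this read-out lower numbers stand for higher toxicity in this test and higher numbers for lower toxicity in this test:

- Compound 1 `CC1=CC[C@@H]([C@@](C)(O)CCCC(C)(C)NC=S)CC1`: > 100000 nM
- Compound 2 `COc1ccc(/C=N\NC(=S)NC(C)(C)CCC[C@](C)(O)[C@@H]2CC=C(C)CC2)cc1`: > 100000 nM

Neither entry is a true number. Compound 2 gives only a limit, > 100000 nM. Compound 1 also gives only a limit, > 100000 nM. All the data so far amount to the limit of > 100000 nM in this assay, at which 2 of the 2 values shown sit, so no order can be drawn between the two compounds.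

The next compound to examine is compound 3 `CC1=CC[C@@H]([C@@](C)(O)CCCC(C)(C)NC(=S)N/N=C\c2ccccc2Cl)CC1`. It differs from compound 2 in one place, with 2-chlorophenyl in place of 4-methoxyphenyl on a carbon with a double bond to nitrogen.

Within the data shown here, no measured pair shows what a swap of this kind does in this assay. The expectation therefore rests on compound 2 alone, and it is for no change beyond the usual scatter. If a real change does appear, it is expected to be toward a lower number, meaning higher toxicity, since compound 2 sits at a limit. The expected step is a number no higher from compound 2 to compound 3 (the limit leaves the size open). For compound 3 the estimate is 100000 nM, with an expected range of 40000 nM to 200000 nM.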

Compound 3, concentration lethal to 50% of the cells: > 100000 nM
Compound 3: a limit, no number; the forecaster's own chance of this, stated with the estimate: 75%; the middle value lies on the limit itself.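

Compound 2 and compound 3 both give only a limit in this assay, so no step can be read between them for 2-chlorophenyl in place of 4-methoxyphenyl. The compounds shown leave open whether any group at this place would give a true number, as every result so far is the same: the limit of > 100000 nM in this assay, at which 3 of the 3 values shown sit.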